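Amide nitrogen substituents on the shared core, paw edema

The source may report more compounds than this note shows. Statements on the series, on what has been measured and on what is new or still open speak of the compounds shown alone.

Measured so far:
compound 1 `COc1cc2c(cc1OC)C(CC(=O)N(C)C)CC2` 34.8%
compound 2 `COc1cc2c(cc1OC)C(CC(=O)NC1CCCC1)CC2` 43.5%

Among the measured compounds shown here, in a functional assay on the whole organism (strain Wistar) for inhibition, with Rattus norvegicus as the target, read by paw edema, with stated times of 60 min and 3 h, at a dose of 100 mg/kg by the oral route (a lower number here means less inhibition, a higher number more inhibition at the dose given (going by the name of the read-out)), compound 2 gives the highest of the two numbers, yet the only step, a number 8.7 percentage points higher from compound 1 to compound 2 (within the scatter), lies within the scatter, so no order between compound 1 and compound 2 can be read.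

Compound 3 `COc1cc2c(cc1OC)C(CC(=O)NCc1ccccc1)CC2` differs from compound 2 in one place: benzyl in place of cyclopentyl on an amide-type nitrogen. For the measured compounds named here, the single measured step bearing on changes at the amide-type nitrogen, a number 8.7 percentage points higher from compound 1 to compound 2 (within the scatter), was within the scatter. A step within the scatter is therefore expected again, a number 1.5 percentage points higher from compound 2 to compound 3 (within the scatter).

For compound 3 the expected value in this assay is 45%, estimated between 30% and 60%.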

Compound 3, a percentage reported as inhibition, in the whole organism at one dose (the size of the read-out at that dose, not a potency): 14.5%
For compound 3 the middle estimate is 30.5 percentage points above the measured one, and the stated range ends above it.
By their numbers in this assay, from the lowest: compound 3; then compounds 1 and 2 (each within the scatter of the next).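

Benzyl in place of cyclopentyl gives a number 29 percentage points lower from compound 2 to compound 3 (beyond the scatter) in this assay, and benzylamino in place of dimethylamino gives a number 20.3 percentage points lower from compound 1 to compound 3 (beyond the scatter) in the same read-out. Both steps lie beyond the scatter, so the group on the amide-type nitrogen does matter here, which compound 1 and compound 2 alone could not show. No measurement on hand explains this drop. Still open, from the compounds shown here alone, is whether the drop follows the aromatic ring itself or the benzyl group as a whole; phenyl or phenethyl on the same nitrogen would bear on that.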